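This account rests on a few compounds, and the source may have more. Where it says the series, first, only, none or still open, it means among the compounds named here.

Compound 2 `CCOc1ccc(NC2=C(C(=O)c3ccccc3)C(c3ccc(Br)cc3)N(CCCn3ccnc3)C2=O)cc1` is one of two close analogues measured in a functional assay on SAOS-2 cells (Homo sapiens) for antiproliferative activity, read by MTT assay, with a stated time of 72 h (on this read-out lower numbers stand for stronger inhibition and higher numbers for weaker inhibition), where compound 2 gives 30900 nM. Going by the values given here, its neighbour, compound 1 `Cc1ccc(NC2=C(C(=O)c3ccccc3)C(c3ccc(Br)cc3)N(CCCn3ccnc3)C2=O)cc1`, gives 31900 nM in this assay, so the two numbers lie within the scatter of each other; the only measured step, a 1.0-fold lower number from compound 1 to compound 2 (0.01 log units; within the scatter), left the read-out unchanged. Compound 3 `O=C(C1=C(Nc2ccc(F)cc2)C(=O)N(CCCn2ccnc2)C1c1ccc(Br)cc1)c1ccccc1` is the next member to be tested. It differs from compound 2 by fluoro in place of ethoxy on an aromatic carbon. Among the compounds with values here, the one step available bears directly on this position on the ring, since it swapped one neutral group for another there, and it was flat. Within the data shown here, with only that step as a guide, compound 3 is expected to behave like its two predecessors, with a 1.0-fold higher number from compound 2 to compound 3 (0.00 log units; within the scatter) as the estimated step in this assay. Compound 3 is therefore estimated at 31000 nM, with a range from 12000 nM to 80000 nM.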

Compound 3, half-maximal inhibitory concentration: 32700 nM
Estimate against measurement, compound 3: 1.1-fold (0.02 log units) below; low and high end bracket the measured number.
By their numbers in this assay, from the lowest: compounds 2, 1 and 3 (each within the scatter of the next).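

In this assay, fluoro in place of ethoxy gives a 1.1-fold higher number from compound 2 to compound 3 (0.02 log units; within the scatter), and fluoro in place of methyl gives a 1.0-fold higher number from compound 1 to compound 3 (0.01 log units; within the scatter). The earlier pair compared only ethoxy with methyl; compound 3 extends the flat result on this aromatic carbon to a single fluorine atom, so groups of one to three heavy atoms, with and without a hydrogen-bond acceptor, all stay within the scatter of one another. No evidence is available to explain this lack of response.

The compounds shown leave open whether an amine, a carboxylic acid or a chain longer than ethoxy on this carbon would also stay within the scatter. They also leave open whether a change elsewhere on the shared core would move the number in this assay.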